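The source may report more compounds than this note shows. Statements on the series, on what has been measured and on what is new or still open speak of the compounds shown alone.

Measured compounds and their values in a functional assay on HepG2 cells (Homo sapiens) for cytotoxicity, read by MTT assay, with a stated time of 48 h; on this read-out lower numbers stand for stronger inhibition and higher numbers for weaker inhibition:

Compound 1, `CC(=O)Nc1ccc2nc(SCC(=O)NCc3ccccc3)sc2c1`, gives 9200 nM.
Compound 2, `COc1ccc(CNC(=O)CSc2nc3ccc(NC(=O)c4ccccc4)cc3s2)cc1`, gives 12700 nM.
Compound 3, `CNC(=O)CSc1nc2ccc(NC(=O)c3ccc(Cl)cc3)cc2s1`, gives 15300 nM.

Compound 3 shows the highest of the three numbers, but its gap to compound 2 and its gap to compound 1 both lie within the usual scatter of repeated measurements, so the three compounds are not separated from one another on this read-out. Compound 4, `CNC(=O)CSc1nc2ccc(NC(=O)CCl)cc2s1`, has not yet been measured. It differs from compound 3 in one place: chloromethyl in place of 4-chlorophenyl on a carbonyl carbon. Among the measured compounds shown here, no pair among the measured compounds differs in just one place, so there is no measured step of this kind to lean on. The step from compound 3 to compound 4 is expected to be modest, estimated as a 2.2-fold lower number from compound 3 to compound 4 (0.34 log units; beyond the scatter), in the direction of a lower number, with wide uncertainty. On that basis compound 4 is expected to give about 7000 nM in this assay, in a range from 2000 nM to 25000 nM.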

Compound 4, half-maximal inhibitory concentration: 1900 nM
Estimate against measurement, compound 4: 3.7-fold (0.57 log units) above; the measured number lies below the stated range.
By their numbers in this assay, from the lowest: compound 4; then compounds 1, 2 and 3 (each within the scatter of the next).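

Among the compounds shown here, with only one change made, an 8.1-fold lower number from compound 3 to compound 4 (0.91 log units; beyond the scatter) in this assay, and this step lies beyond the scatter. For the compounds shown here, it shows that the group on this carbonyl carbon can shift the number, something the earlier compounds could not show: no two of them differed in just one place, and their numbers lay within the scatter of one another. Nothing measured here says why the number falls on going from 4-chlorophenyl to chloromethyl.

This single pair cannot separate the loss of the aromatic ring from the presence of chloromethyl itself. A dimethylaminomethyl group or a longer chain such as 2-chloroethyl on the same carbonyl carbon would show whether the lower number depends on the chlorine, or on the chain length.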